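Bromo on compound 2: expected growth inhibition

A few compounds are considered here, and "the series" means these few. Any claim that something is new, unique, unknown or untested is made for them only; others in the source may bear on it.

In a functional assay on HT-29 cells (Homo sapiens) for inhibition, read by spectrophotometry and sulforhodamine B assay, with a stated time of 48 h (a lower number here means a stronger inhibitor of growth, a higher number a weaker inhibitor of growth), compound 2 `O=C1CS/C(=N/N=C/c2c[nH]c3ccccc23)N1c1cccc2ccccc12` gives 96900 nM as the higher of the two numeric values, and compound 3 `Cc1ccc(NC(=S)N/N=C/c2c[nH]c3ccccc23)cc1` gives 1450 nM with a gap beyond the scatter. Compound 1 `Cc1ccc(N2C(=O)CS/C2=N/N=C/c2c[nH]c3ccc(Br)cc23)cc1` also carries bromo and gives > 100000 nM as a limit of the assay and not a number. Compound 4 `O=C1CS/C(=N/N=C/c2c[nH]c3ccc(Br)cc23)N1c1cccc2ccccc12` differs from compound 2 by bromo in place of hydrogen on an aromatic carbon with bromo in place of hydrogen on an aromatic carbon. Among the measured compounds shown here, no measured pair isolates this change, and compound 2 at 96900 nM is already a weak inhibitor of growth, so no step beyond the scatter is expected in this assay here. The expected step is a 1.0-fold higher number from compound 2 to compound 4 (0.01 log units; within the scatter) and stays within the scatter. For compound 4 the estimated value is 100000 nM with a range from 40000 nM to 250000 nM and a real chance of only a limit.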

Compound 4, concentration for 50% growth inhibition: 27300 nM
Compound 4: middle estimate off by 3.7-fold (0.56 log units), on the high side, and the stated range ends above it.
By their numbers in this assay, from the lowest: compound 3; then compound 4; then compound 2. At a limit, above all of these: compound 1.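

In this assay, among the compounds shown here, bromo in place of hydrogen on an aromatic carbon gives a 3.5-fold lower number from compound 2 to compound 4 (0.55 log units; beyond the scatter) as the first single-place step, so this position, meta to a fused ring and para to a fused ring, responds to substitution. The gain is modest and leaves compound 4 a weak inhibitor of growth. Compound 1 carries bromo at the same position and gives > 100000 nM as a limit of the assay and not a number.

As far as these compounds go, whether chloro, methoxy or an amine at this position would act as bromo does remains open. So does the size of any bromo step on compound 3.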